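The source may report more compounds than this note shows. Statements on the series, on what has been measured and on what is new or still open speak of the compounds shown alone.

Measured so far: compound 1 `C=CC(=O)Nc1cccc(NC(=O)CSc2nc(Nc3cccc(F)c3)c3ccccc3n2)c1` gives 2030 nM in a functional assay on NCI-H1975 cells (Homo sapiens) for inhibition, read by MTT assay, with a stated time of 72 h; a lower number here means a stronger inhibitor, a higher number a weaker inhibitor; compound 2 `C=CC(=O)Nc1cccc(NC(=O)CSc2nc(Nc3cccc([N+](=O)[O-])c3)c3ccccc3n2)c1` gives 22600 nM; compound 3 `C=CC(=O)Nc1cccc(NC(=O)CSc2nc(Nc3ccc(Br)cc3)c3ccccc3n2)c1` gives 6280 nM.

Compound 3 stands second highest of the three numbers, sitting between the others: a 3.1-fold higher number from compound 1 to compound 3 (0.49 log units; beyond the scatter), and a 3.6-fold lower number from compound 2 to compound 3 (0.56 log units; beyond the scatter). Compound 4 is `C=CC(=O)Nc1cccc(NC(=O)CSc2nc(Nc3cc(OC)c(OC)c(OC)c3)c3ccccc3n2)c1`; it differs from compound 3 by 3,4,5-trimethoxyphenyl in place of 4-bromophenyl on a nitrogen on an aromatic ring. Among the measured compounds shown here, the steps that bear on this are the two earlier exchanges of the group on that same nitrogen, both modest, while the nitro-for-fluoro exchange, an 11-fold higher number from compound 1 to compound 2 (1.05 log units; beyond the scatter), was large. For the measured compounds named here, no measured compound carries a trimethoxyphenyl there, so the direction is open; a modest step is expected, a 1.3-fold higher number from compound 3 to compound 4 (0.11 log units; within the scatter). Compound 4 is therefore estimated at 8000 nM, expected to fall between 2500 nM and 25000 nM.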

Compound 4, half-maximal inhibitory concentration: > 50000 nM
Compound 4 gave a limit, no number; the forecaster's own chance of this, stated with the estimate: 5%; middle value at least 6.2-fold (0.79 log units) away from the limit.
By their numbers in this assay, from the lowest: compound 1; then compound 3; then compound 2. At a limit, above all of these: compound 4.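

Compound 4 gave only a limit in this assay, not a number: the limit of > 50000 nM in this assay, at which 1 of the 4 values shown sits. Read against that limit, the 3,4,5-trimethoxyphenyl group on this nitrogen gives an at least 7.9-fold higher number from compound 3 to compound 4 (0.90 log units; beyond the scatter), an at least 2.2-fold higher number from compound 2 to compound 4 (0.34 log units; beyond the scatter) and an at least 24-fold higher number from compound 1 to compound 4 (1.39 log units; beyond the scatter). This change therefore takes the number past that of every earlier compound, including compound 2, so the group on this nitrogen can cost more activity than the exchange to 4-bromophenyl did. On these data alone, whether a single methoxy group on the phenyl ring has the same effect, or only all three together, remains open. As far as these compounds go, how a phenyl ring carrying an amine would behave here also remains open.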